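The source may report more compounds than this note shows. Statements on the series, on what has been measured and on what is new or still open speak of the compounds shown alone.

Working notes on the series

Compound 1 `N=S1(=O)c2ccccc2C(=O)N1c1ccccc1` is the reference point of this step. In an ADME assay on a cell-free system (plasma, Homo sapiens) for protein binding (on this read-out lower numbers stand for a smaller free fraction and higher numbers for a larger free fraction), compound 1 has no result: the entry for compound 1 reads "not determined" (no result reported), so compound 1 stands on no number at all. The same holds for compound 3 `CCN1C(=O)c2ccccc2S1(=O)=O`, for which the entry in this assay reads "not determined" (no result reported). Going by the values given here, the only number in the set belongs to compound 2 `NC1=NS(=O)(=O)c2ccccc21`, which in this assay gives 0.48. Among the compounds with values here, with no step between two measured compounds, nothing can be said about how a change in this core moves the unbound fraction; compound 2 alone marks where one member of the series sits.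

Compound 4 `CCN1C(=O)c2ccccc2S1(=N)=O` is reached from compound 1 by the change (ethyl in place of phenyl on an amide-type nitrogen in a ring), on an amide-type nitrogen in a ring, next to the ring sulfur. Within the data shown here, since compound 1 has no number, the size of this step in this assay cannot be read from the data; the expectation is for no movement beyond the usual scatter relative to the only measured neighbour, compound 2, with 0.48 as the anchor.

For compound 4 in this assay the estimated unbound fraction is 0.5, expected to fall between 0.25 and 0.85.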

Compound 4, unbound fraction in the plasma assay: 0.83
The estimate for compound 4 lay 1.7-fold (0.22 log units) below the measured number; measured number inside the range.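

Going by these compounds alone, the result for compound 4 in the plasma assay yields no new step: compound 1 has no number there, so the change from compound 1 to compound 4 cannot be read. In a physicochemical assay for acid dissociation, read by spectrophotometry, compound 1 gives 8.3 and compound 4 gives 8.9 with a number 0.60 log units higher from compound 1 to compound 4 (beyond the scatter) as the step between them. From the compounds shown here alone, whether ethyl in place of phenyl moves the result in the plasma assay at all stays open.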